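Solubility of an aminopyridazine in place of a pyridine

A few compounds are considered here, and "the series" means these few. Any claim that something is new, unique, unknown or untested is made for them only; others in the source may bear on it.

Compound 1 `Cc1cc(C)c(-c2cn(C)cn2)cc1NC(=O)c1ccc(OCc2ccccn2)cc1` gives 8000 nM in a physicochemical assay for solubility, at pH 7.4; a higher number here means a more soluble compound, a lower number a less soluble compound. Compound 2 `Cc1cc(C)c(-c2c(C)nn(C)c2C)cc1NC(=O)c1ccc(OCc2ccccn2)cc1` gives 35000 nM in this assay. Compound 3 `Cc1cc(C)c(-c2ccccn2)cc1NC(=O)c1ccc(OCc2ccccn2)cc1` reaches only a limit of the assay in this assay, < 1000 nM. Its standing among the measured compounds follows from an at least 8.0-fold lower number from compound 1 to compound 3 (0.90 log units; beyond the scatter) and from an at least 35-fold lower number from compound 2 to compound 3 (1.54 log units; beyond the scatter), both toward lower numbers; the limit of < 1000 nM in this assay, at which 1 of the 3 values shown sits, marks where compound 3 sits. Compound 4 `Cc1cc(C)c(-c2ccc(N)nn2)cc1NC(=O)c1ccc(OCc2ccccn2)cc1` carries 6-aminopyridazin-3-yl in place of pyridin-2-yl on an aromatic carbon. Within the data shown here, no measured step mirrors this particular change; the two steps that lead to compound 3 were at least modest and large, so a step in this assay beyond the scatter toward a higher number is expected, estimated as an at least 3.0-fold higher number from compound 3 to compound 4 (0.47 log units; beyond the scatter). Compound 4 is expected to give about 3000 nM in this assay, within 800 nM to 15000 nM.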

Compound 4, solubility: 6000 nM
The estimate for compound 4 lay 2.0-fold (0.30 log units) below the measured number, within the range that was stated.
By their numbers in this assay, from the lowest: compounds 4 and 1 (each within the scatter of the next); then compound 2. At a limit, below all of these: compound 3.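

In this assay, placing 6-aminopyridazin-3-yl on the aromatic carbon ortho to a methyl group gives an at least 6.0-fold higher number from compound 3 to compound 4 (0.77 log units; beyond the scatter). A six-membered aromatic ring at this position therefore need not stay at the limit, and a 1.3-fold lower number from compound 1 to compound 4 (0.12 log units; within the scatter) leaves it level with the 1-methyl-1H-imidazol-4-yl group. The 1,3,5-trimethyl-1H-pyrazol-4-yl group keeps a clear margin, with a 5.8-fold lower number from compound 2 to compound 4 (0.77 log units; beyond the scatter).

From the compounds shown here alone, the value of compound 3 is a limit of the assay, so the full size of its step stays open: the limit of < 1000 nM in this assay, at which 1 of the 4 values shown sits. Whether the step follows the amine or the ring also stays open, as does what a dimethylamino group in place of the amine would give.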